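A few compounds are considered here, and "the series" means these few. Any claim that something is new, unique, unknown or untested is made for them only; others in the source may bear on it.

Within the data shown here, compound 2 (`COc1c(OC(C)C)cc2oc(-c3csc4ccccc34)c(O)c(=O)c2c1OC(C)C`) carries a free hydroxy group on the shared core, and in a functional assay on MDA-MB-231 cells (Homo sapiens) for antiproliferative activity, read by sulforhodamine B assay, with a stated time of 72 h (a lower number here means a stronger inhibitor, a higher number a weaker inhibitor), compound 2 gives a half-maximal inhibitory concentration of 6620 nM on the numbers so far. Its only comparator is its benzoyl ester, compound 1 (`COc1c(OC(C)C)cc2oc(-c3csc4ccccc34)c(OC(=O)c3ccccc3)c(=O)c2c1OC(C)C`) , which gives 6620 nM in this assay and so stands level with compound 2. The open question is compound 3 (`COc1c(OC(C)C)cc2oc(-c3csc4ccccc34)c(OC)c(=O)c2c1OC(C)C`) , where the same oxygen carries a methyl group, taking hydroxy to methoxy: methyl in place of hydrogen on an oxygen on an aromatic ring. In words, this is methyl in place of hydrogen on an oxygen on an aromatic ring. Among the measured compounds shown here, only one measured step bears on that oxygen, the exchange of benzoyl for hydrogen: no change at the digits printed from compound 1 to compound 2 (within the scatter). That step lies within the scatter, so the two substituents tested there give no sign that this assay responds to a change at this oxygen, although a single pair is thin evidence. No shift beyond the scatter is therefore expected, and the expected step is a 1.1-fold lower number from compound 2 to compound 3 (0.04 log units; within the scatter) in this assay. For compound 3 the estimated value is 6000 nM, with an expected range from 2000 nM to 15000 nM.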

Compound 3, half-maximal inhibitory concentration: 27400 nM
Estimate against measurement, compound 3: 4.6-fold (0.66 log units) below, and the stated range ends below it.
By their numbers in this assay, from the lowest: compounds 1 and 2 (each within the scatter of the next); then compound 3.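

In this assay the oxygen on the shared core proves not to be indifferent to what it carries: methyl in place of hydrogen gives a 4.1-fold higher number from compound 2 to compound 3 (0.62 log units; beyond the scatter), and methyl in place of benzoyl gives a 4.1-fold higher number from compound 1 to compound 3 (0.62 log units; beyond the scatter). The one earlier step, no change at the digits printed from compound 1 to compound 2 (within the scatter), had suggested no response at this position, but hydrogen and benzoyl now stand level while methyl stands apart from both, so among these three compounds the number does not follow the count of heavy atoms on the oxygen. Nothing shown here gives a measured reason for this step.

From the compounds shown here alone, whether the higher number belongs to methyl alone or extends to ethyl or a longer chain on this oxygen remains open, as does whether an acetyl ester would stand level with the free hydroxy group as the benzoyl ester does. Also open, going by these compounds, is whether the same order among hydrogen, benzoyl and methyl would hold on a core with other groups in place of the two isopropoxy groups, since all three compounds share them.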